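A few compounds are considered here, and "the series" means these few. Any claim that something is new, unique, unknown or untested is made for them only; others in the source may bear on it.

Of the compounds shown here, two have been measured in an assay on HEK293 cells for positive allosteric modulation of metabotropic glutamate receptor 2 (Rattus norvegicus), read by thallium flux, with a stated time of 2.5 min; a higher number here means a larger maximal response, a lower number a smaller maximal response. Compound 1, `CCC(=O)c1ccc(OCCCCOc2cc(C(=O)O)ccc2OC)c(C)c1O`, gives 72.6%. Compound 2, `Cc1ccc(C(=O)O)cc1OCCCCOc1ccc(C(=O)CC(C)C)c(O)c1C`, gives 76.9%. Within the data shown here, compound 2 stands highest of the two numbers, yet its only neighbour, compound 1, lies within the usual scatter of it, and the two cannot be told apart on these data. Compound 3, `COc1ccc(C(=O)O)cc1OCCCCOc1ccc(C(=O)CC(C)C)c(O)c1C`, has not yet been measured. It differs from compound 2 in one place: methoxy in place of methyl on an aromatic carbon. Among the measured compounds shown here, no step between measured compounds is known. The data give no hint of how a methoxy in place of a methyl on an aromatic carbon would shift the maximal response, and the expected step is accordingly small, a number 1.9 percentage points lower from compound 2 to compound 3 (within the scatter), none beyond the scatter in either direction. Compound 3 is expected to reach about 75%, with a likely range from 60% to 90%.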

Compound 3, largest response reached (reported as percent of maximum), in percent of the reference or control that the assay uses: 89.7%
Compound 3: the middle estimate sits 14.7 percentage points below what was measured; the measured number falls inside the stated range.
By their numbers in this assay, from the lowest: compounds 1 and 2 (each within the scatter of the next); then compound 3.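

On the aromatic carbon para to a carboxy group, methoxy in place of methyl is shown to move the maximal response beyond the scatter in this assay (a number 12.8 percentage points higher from compound 2 to compound 3 (beyond the scatter)). With methoxy kept at that place, isopropyl in place of methyl on a saturated chain carbon bound to a carbonyl carbon also gives a change beyond the scatter (a number 17.1 percentage points higher from compound 1 to compound 3 (beyond the scatter)), so in these two pairs, changes in two separate places each register in this read-out. Nothing available explains why either change acts as it does.

The compounds shown leave open whether the rise belongs to methoxy alone, or would also come with an ethoxy or a chlorine at that aromatic carbon. They also leave open whether a cyclopropyl in place of the isopropyl would keep the response.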